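Filling an open ring position with a chlorothiophene

The source may report more compounds than this note shows. Statements on the series, on what has been measured and on what is new or still open speak of the compounds shown alone.

The series centres on compound 2, `CCOC(=O)c1cnc(NN2C(=O)C=C(C)C2=O)nc1`, a hydrazine-linked pyrimidine ester whose six-membered ring carries only hydrogen at one open aromatic carbon. In a functional assay on Jurkat cells (Homo sapiens) for inhibition (a higher number here means a weaker inhibitor, a lower number a stronger inhibitor), compound 2 gives 13000 nM, the highest number of the two values recorded, so it is the weaker of the pair. Going by the values given here, its neighbour compound 1, `CCOC(=O)c1cnc(N(C(=O)OCC)N2C(=O)C=C(C)C2=O)nc1C(F)(F)F`, differs in two places at once and in this assay gives 380 nM, a far lower number; because the two structures differ in more than one place, the comparison shows only that the more elaborated compound is the stronger inhibitor here.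

Compound 3, `CCOC(=O)c1cnc(NN2C(=O)C=C(C)C2=O)nc1-c1ccc(Cl)s1`, makes a single change to compound 2: 5-chlorothiophen-2-yl in place of hydrogen on an aromatic carbon. Among the compounds with values here, no measured pair isolates this kind of change, so its effect has to be guessed. Within the data shown here, the one comparison available, between compound 1 and compound 2, suggests that building out the core tends to lower the number. A moderate improvement is therefore expected, a 5.2-fold lower number from compound 2 to compound 3 (0.72 log units; beyond the scatter), beyond the usual scatter but well short of what compound 1 shows. Compound 3 is estimated at 2500 nM, within a range from 500 nM to 12000 nM.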

Compound 3, half-maximal inhibitory concentration: 520 nM
For compound 3 the middle estimate is 4.8-fold (0.68 log units) above the measured one; low and high end bracket the measured number.
By their numbers in this assay, from the lowest: compounds 1 and 3 (each within the scatter of the next); then compound 2.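

In this assay, 5-chlorothiophen-2-yl in place of hydrogen gives a 25-fold lower number from compound 2 to compound 3 (1.40 log units; beyond the scatter), a large change from one substitution on the aromatic carbon next to the ring nitrogen and ortho to the ethoxycarbonyl group. The earlier comparison could not show this, as compound 1 differs from compound 2 in two places at once, leaving the contribution of each place unknown. Here only one place differs, so this open carbon is shown on its own to be a position where a substituent can strongly alter the number in this assay, while nothing available bears on why the step is so large.

The compounds shown leave open which part of the new group matters: a plain thiophen-2-yl without the chlorine, a phenyl ring or a small methyl on the same carbon would help to separate the role of the chlorine, the thiophene and simple filling of the position. Going by these compounds alone, they also leave open what a trifluoromethyl group does at this carbon when it is the only change to compound 2, with the hydrazine nitrogen left unsubstituted.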